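This account rests on a few compounds, and the source may have more. Where it says the series, first, only, none or still open, it means among the compounds named here.

Compound 2 `O=c1oc2ccccc2c(=O)n1-c1ccc(F)cc1F` was examined in an ADME assay on RAW264.7 cells (Mus musculus) for cytotoxicity, read by MTT assay, with a stated time of 24 h; on this read-out higher numbers stand for lower toxicity in this test and lower numbers for higher toxicity in this test. In this assay compound 2 gives > 40000 nM, which is a limit of the assay rather than a number. Compound 1 `COc1ccc2c(=O)n(-c3ccc(Cl)cc3F)c(=O)oc2c1` likewise gives > 40000 nM, also a limit. Both readings sit at the limit of > 40000 nM in this assay, at which 2 of the 2 values shown sit, so compound 2 stands with compound 1 at the edge of what the test can show. Compound 3 `COc1ccc2c(=O)n(-c3ccc(F)cc3F)c(=O)oc2c1` differs from compound 2 by methoxy in place of hydrogen on an aromatic carbon. No shift beyond the scatter is expected, a step that the limit leaves unreadable from compound 2 to compound 3, because both known readings sit at the limit of > 40000 nM in this assay, at which 2 of the 2 values shown sit. Compound 3 is therefore estimated at 60000 nM, most likely between 30000 nM and 200000 nM.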

Compound 3, half-maximal cytotoxic concentration: > 40000 nM
Compound 3 was reported as a limit; the forecaster's own chance of this, stated with the estimate: 85%; the middle value lies beyond the limit too.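

No step can be read between compound 1, compound 2 and compound 3, because all three readings are limits and not numbers: the limit of > 40000 nM in this assay, at which 3 of the 3 values shown sit.

On these data alone, whether methoxy in place of hydrogen, or fluoro in place of chloro, changes the reading in this assay stays open.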